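The source may hold more compounds than are shown below. What is called first, only, known or untested is meant among the compounds shown, and "the series" means these compounds.

Compound 1 `Cc1ccc(NS(=O)(=O)c2cc(C(=O)NCc3nc(C)no3)ccc2C)cc1` was tested in an ADME assay on MDCK-II cells (Canis lupus familiaris) for permeability (a lower number here means that the compound crosses the layer more slowly, a higher number that the compound crosses the layer faster), where compound 1 gives 20 10^-6 cm/s. Compound 2 `Cc1ccc(NS(=O)(=O)c2cccc(C(=O)NCc3nc(C)no3)c2)cc1` is its closest neighbour among the measured compounds; in this assay compound 2 gives 22 10^-6 cm/s. Among the compounds with values here, the only measured step is a 1.1-fold higher number from compound 1 to compound 2 (0.04 log units; within the scatter), which removes a methyl group from an aromatic carbon. On these two numbers compound 1 stands as the lowest of the two, with compound 2 not separable from it.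

The next compound, compound 3 `Cc1noc(CNC(=O)c2ccc(C)c(S(=O)(=O)Nc3ccc(-c4cnco4)cc3)c2)n1`, differs from compound 1 by 1,3-oxazol-5-yl in place of methyl on an aromatic carbon. Within the data shown here, the single measured step bears on this change only loosely, since it removes a small group rather than adding a ring, and it was itself too small to read. The data therefore give little guidance; a moderate shift downward in this assay is the expectation here, estimated as a 1.7-fold lower number from compound 1 to compound 3 (0.22 log units; within the scatter). For compound 3 the expected value is 12 10^-6 cm/s, within a range from 5 10^-6 cm/s to 25 10^-6 cm/s.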

Compound 3, apparent permeability: 10 10^-6 cm/s
Estimate against measurement, compound 3: 1.2-fold (0.08 log units) above; the range from low to high includes it.
By their numbers in this assay, from the lowest: compounds 3, 1 and 2 (each within the scatter of the next, the first and the last beyond it).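

Swapping the methyl for 1,3-oxazol-5-yl on this aromatic carbon, para to a large group, is a far larger change than the earlier step, which removed a methyl from a different aromatic carbon: five heavy atoms and a whole aromatic ring enter where one carbon left, bringing two hydrogen-bond acceptors. Even so, in this assay the step stays within the scatter (a 2.0-fold lower number from compound 1 to compound 3 (0.30 log units; within the scatter)), so on this single pair the place accepts a ring of this size without a readable change in the number. Nothing measured here accounts for this result.

The compounds shown leave open how a group with a different character, such as an amine or a carboxylic acid, would read at this place. They also leave open whether a plain phenyl ring, without hetero atoms, would read the same as 1,3-oxazol-5-yl.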